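This account rests on a few compounds, and the source may have more. Where it says the series, first, only, none or still open, it means among the compounds named here.

Measured so far:
compound 1 `O=C1Nc2ccc(C(=O)c3ccco3)cc2/C1=C/c1ccc(Br)c(O)c1` — -5.6%
compound 2 `COc1ccc(/C=C2\C(=O)Nc3ccc(C(=O)c4ccco4)cc32)cc1Br` — 2.3%
compound 3 `O=C1Nc2ccc(C(=O)c3ccco3)cc2/C1=C/c1ccc(O)c(Br)c1` — 23%

In an assay on HeLa cells for inhibition of Kinesin-like protein KIF15 (Homo sapiens), read by microscopy, with stated times of 2 s and 20 s, tested at 750 nM (a lower number here means less inhibition, a higher number more inhibition at the concentration tested (going by the name of the read-out)), compound 3 stands highest of the three numbers; the nearest is compound 2, lower beyond the scatter, and the furthest is compound 1. The rise a number 20.7 percentage points higher from compound 2 to compound 3 (beyond the scatter) and the rise a number 28.6 percentage points higher from compound 1 to compound 3 (beyond the scatter) are the two steps that lead up to it.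

Compound 4 `O=C1Nc2ccc(C(=O)c3ccco3)cc2/C1=C/c1ccncc1` is not yet measured. It differs from compound 3 in one place: pyridin-4-yl in place of 3-bromo-4-hydroxyphenyl on a double-bonded chain carbon bound to a double-bonded ring carbon. Among the measured compounds shown here, no measured step removes the whole ring with its bromine and its hydroxyl at once, so the bearing of the known steps is indirect. The step of a number 20.7 percentage points higher from compound 2 to compound 3 (beyond the scatter) shows that exchanging methyl for hydrogen on the oxygen was worth a modest gain, and compound 4 carries neither that oxygen nor the bromine, nor any hydrogen-bond donor on that ring. A fall beyond the scatter in this assay is therefore expected, estimated at a number 23 percentage points lower from compound 3 to compound 4 (beyond the scatter). For compound 4 the expected value in this assay is 0%, in a range from -15% to 15%.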

Compound 4, a percentage reported as inhibition, at one concentration (the size of the read-out at that concentration, not a potency): 0.8%
For compound 4 the middle estimate is 0.8 percentage points below the measured one; low and high end bracket the measured number.
By their numbers in this assay, from the lowest: compounds 1, 4 and 2 (each within the scatter of the next); then compound 3.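

In this assay, exchanging the whole ring on the double-bonded chain carbon bound to a double-bonded ring carbon shows that pyridin-4-yl does not keep what 3-bromo-4-hydroxyphenyl gave, with a number 22.2 percentage points lower from compound 3 to compound 4 (beyond the scatter) and thus a modest loss. Set against the other two rings, the same exchange gives a number 1.5 percentage points lower from compound 2 to compound 4 (within the scatter) and also a number 6.4 percentage points higher from compound 1 to compound 4 (within the scatter) and so separates compound 4 from neither compound 2 nor compound 1. Among these four compounds, only 3-bromo-4-hydroxyphenyl stands apart at this position, while a ring with neither bromine nor hydroxyl reads alike with 3-bromo-4-methoxyphenyl and 4-bromo-3-hydroxyphenyl.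

Still open, from the compounds shown here alone, is whether an amine or a carboxylic acid on the phenyl ring could take the place of the hydroxyl, or whether chlorine could take the place of the bromine. Nothing available here explains the difference between these rings.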